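Side-chain swap at the ester-bearing carbon, third analogue

This account rests on a few compounds, and the source may have more. Where it says the series, first, only, none or still open, it means among the compounds named here.

Two compounds of the series have measured numbers. Compound 1 `NCCCC[C@H](NC(=O)CN(c1nc(Cl)nc2[nH]cnc12)C1CC1)C(=O)OCc1ccccc1` gives 41.2% in a functional assay on the whole organism (Tail, strain ICR) with Mus musculus as the target, in the tail flick test, with a stated time of 60 min, at a dose of 25 umol/kg by the oral route; a higher number here means a stronger effect of the compound at the dose given, a lower number a weaker effect. Compound 2 `CC[C@H](C)[C@H](NC(=O)CN(c1nc(Cl)nc2[nH]cnc12)C1CC1)C(=O)OCc1ccccc1` gives 40.6% in this assay. The one step between measured compounds is a number 0.6 percentage points lower from compound 1 to compound 2 (within the scatter); on the numbers shown, compound 2 and compound 1 cannot be told apart, and neither can be called the more active of the two.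

Compound 3 `NC(=O)CC[C@H](NC(=O)CN(c1nc(Cl)nc2[nH]cnc12)C1CC1)C(=O)OCc1ccccc1` is not yet measured. It differs from compound 2 as follows: 2-carbamoylethyl in place of sec-butyl on a saturated chain carbon bound to an amide-type nitrogen and a carbonyl carbon. Among the compounds with values here, the only measured step concerns the same place, where one side chain replaced another and the read-out stayed within the scatter. Within the data shown here, that step is the sole guide here, and it points to no movement beyond the scatter for the present change.

The expected step is therefore a number 0.6 percentage points lower from compound 2 to compound 3 (within the scatter) for compound 3. The estimate for compound 3 in this assay is 40%, with a range from 25% to 55%. Among the measured compounds shown here, only one prior step supports this, and the range is kept wide to reflect that.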

Compound 3, a percentage reported as activity, at one dose (the size of the read-out at that dose, not a potency): 33.1%
Compound 3: middle estimate off by 6.9 percentage points, on the high side; low and high end bracket the measured number.
By their numbers in this assay, from the lowest: compounds 3, 2 and 1 (each within the scatter of the next).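

With 2-carbamoylethyl in place of sec-butyl on the saturated chain carbon bound to an amide-type nitrogen and a carbonyl carbon, this assay gives a number 7.5 percentage points lower from compound 2 to compound 3 (within the scatter) for this change, and the comparison with the amine-bearing side chain of compound 1 gives a number 8.1 percentage points lower from compound 1 to compound 3 (within the scatter) for the side-chain end. These are larger steps than the first one in the series, a number 0.6 percentage points lower from compound 1 to compound 2 (within the scatter) at the same position, yet all three compounds still cannot be told apart, so this position has now taken sec-butyl, with no hydrogen-bond donor or acceptor, and 2-carbamoylethyl, with one of each, without a step beyond the scatter. Nothing available bears on the reason for the size of these steps.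

Open, on these data alone, is whether any side chain at this carbon moves the read-out beyond the scatter: a carboxylic acid at the end of the chain, a benzyl group or a shorter chain such as methyl would test that. Since the read-out comes from a single dose, the compounds shown also leave open how their potencies compare.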